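Methoxy for chloro on the aryl of a shared core

The source may hold more compounds than are shown below. What is called first, only, known or untested is meant among the compounds shown, and "the series" means these compounds.

Compound 1 `CC(c1ccc(-c2ccccc2)c(F)c1)c1nnc2n1N=C(c1ccc(Cl)cc1)CS2`: 5000 nM
Compound 2 `CC(C)Cc1ccc(C(C)c2nnc3n2N=C(c2ccc(OC(F)(F)F)cc2)CS3)cc1`: 8800 nM

Of the compounds shown here, two have been measured in a functional assay on FOCUS cells (Homo sapiens) for inhibition, read by sulforhodamine B assay, with a stated time of 72 h; on this read-out lower numbers stand for stronger inhibition and higher numbers for weaker inhibition. Compound 1 gives 5000 nM, and compound 2 gives 8800 nM. The two numbers lie within the usual scatter of each other, so compound 1 stands beside compound 2 rather than apart from it, and no ranking can be drawn from them. The two structures differ in several places, so their values show only that both sit in the same range.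

Compound 3 `COc1ccc(C2=Nn3c(nnc3C(C)c3ccc(-c4ccccc4)c(F)c3)SC2)cc1` has not yet been measured. It differs from compound 1 in one place: methoxy in place of chloro on an aromatic carbon. No single-point change between measured compounds is available to guide the size of such a step, so the expected step from compound 1 to compound 3 in this assay is a 1.3-fold higher number from compound 1 to compound 3 (0.11 log units; within the scatter), in neither direction beyond the scatter. Compound 3 is therefore expected to give about 6500 nM, within a range of 2500 nM to 18000 nM.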

Compound 3, half-maximal inhibitory concentration: 4400 nM
Compound 3: middle estimate off by 1.5-fold (0.17 log units), on the high side; the range from low to high includes it.
By their numbers in this assay, from the lowest: compounds 3, 1 and 2 (each within the scatter of the next).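

In this assay, within the data shown here, methoxy in place of chloro on an aromatic carbon, para to a large group, gives a 1.1-fold lower number from compound 1 to compound 3 (0.06 log units; within the scatter), and this is the only comparison so far that isolates a single change. On the shared core, the read-out does not separate 4-chlorophenyl from 4-methoxyphenyl, even though methoxy carries a hydrogen-bond acceptor and chloro does not. No measurement at hand speaks to why the two groups read alike.

The compounds shown leave open whether a group of another kind at this place, such as an amine or a carboxylic acid, would stay in the same range. A single pair also cannot show whether the methoxy-for-chloro change would read the same way with different groups elsewhere on the core.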